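The compounds below may be only part of what the source reports. "The series", "measured", "known", "first", "only" and "open" are said of these compounds alone.

Measured so far:
compound 1 `COc1ccc(Oc2ccc3c(NCCCNCc4cccc(OC)c4O)ccnc3c2)cc1`: 317 10^-6 cm/s
compound 2 `COc1cccc(CNCCCNc2ccnc3cc(Cc4ccc(C#N)cc4)ccc23)c1O`: 23 10^-6 cm/s
compound 3 `COc1ccc(Oc2ccc3c(NCCCNCc4ccco4)ccnc3c2)cc1`: 317 10^-6 cm/s

All three numbers come from an ADME assay for permeability, using PAMPA, with a stated time of 30 min, at pH 7.4; a higher number here means that the compound crosses the layer faster, a lower number that the compound crosses the layer more slowly. Compound 2 differs from compound 1 by 4-cyanobenzyl in place of 4-methoxyphenoxy on an aromatic carbon; this change gave a 14-fold lower number from compound 1 to compound 2 (1.14 log units; beyond the scatter). Compound 3 differs from compound 1 by furan-2-yl in place of 2-hydroxy-3-methoxyphenyl on a saturated chain carbon bound to an amine nitrogen, a change that gave no change at the digits printed from compound 1 to compound 3 (within the scatter), so the two cores behave alike in this assay. Compound 4 `N#Cc1ccc(Cc2ccc3c(NCCCNCc4ccco4)ccnc3c2)cc1` is not yet measured; it differs from compound 3 by 4-cyanobenzyl in place of 4-methoxyphenoxy on an aromatic carbon, the same change, at the same place, as that from compound 1 to compound 2. For compound 4 a step of a 13-fold lower number from compound 3 to compound 4 (1.10 log units; beyond the scatter) is expected. This expectation rests on the earlier step of the same change, a 14-fold lower number from compound 1 to compound 2 (1.14 log units; beyond the scatter), applied to the value of compound 3, 317 10^-6 cm/s. Compound 4 is thus estimated at 25 10^-6 cm/s, between 10 10^-6 cm/s and 60 10^-6 cm/s.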

Compound 4, apparent permeability: 23 10^-6 cm/s
Compound 4: the middle estimate sits 1.1-fold (0.04 log units) above what was measured, within the range that was stated.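

In this assay, 4-cyanobenzyl in place of 4-methoxyphenoxy gave a 14-fold lower number from compound 3 to compound 4 (1.14 log units; beyond the scatter), and this step carried over from the core of compound 1 without loss of size: the same change on two cores in this assay, a 14-fold lower number (1.14 log units; beyond the scatter) from compound 1 to compound 2 and a 14-fold lower number (1.14 log units; beyond the scatter) from compound 3 to compound 4, 1.0-fold (0.00 log units) apart, within the scatter of two such steps. The furan-2-yl change, read on the 4-cyanobenzyl compounds, gave no change at the digits printed from compound 2 to compound 4 (within the scatter), so the two changes behave independently across these four compounds: the same change on two cores in this assay, no change at the digits printed (within the scatter) from compound 1 to compound 3 and no change at the digits printed (within the scatter) from compound 2 to compound 4, 1.0-fold (0.00 log units) apart, within the scatter of two such steps. This shows transfer across one pair of cores only, and it does not show why the step occurs or that it will hold on any further core.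

Going by these compounds, whether the step keeps its size with a longer chain on the amine nitrogen remains open. So does the outcome with a carboxylic acid in place of the nitrile.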